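Chloro to trifluoromethyl exchange on the fused ring

This account rests on a few compounds, and the source may have more. Where it says the series, first, only, none or still open, it means among the compounds named here.

Compound 1 `NC(=S)N/N=C1/C(=O)N(CN2CCN(c3ccnc4cc(Cl)ccc34)CC2)c2cccc(Br)c21` and compound 2 `NC(=S)N/N=C1/C(=O)N(CN2CCN(c3ccnc4cc(Cl)ccc34)CC2)c2cc(Cl)ccc21` share much of their structure; the difference between the two cores is not broken down here. Among the compounds with values here, in an ADME assay on MCF-10A cells (Homo sapiens) for cytotoxicity, read by sulforhodamine B assay, with a stated time of 48 h (on this read-out higher numbers stand for weaker inhibition of growth and lower numbers for stronger inhibition of growth), compound 1 gives 29400 nM, and compound 2 gives 64600 nM, the highest of the three numbers measured so far. Compound 3 `NC(=S)N/N=C1/C(=O)N(CN2CCN(c3ccnc4cc(C(F)(F)F)ccc34)CC2)c2cccc(Br)c21` differs from compound 1 in one place, (trifluoromethyl in place of chloro on an aromatic carbon), and in this assay compound 3 gives 30600 nM; the step is a 1.0-fold higher number from compound 1 to compound 3 (0.02 log units; within the scatter). Compound 4 `NC(=S)N/N=C1/C(=O)N(CN2CCN(c3ccnc4cc(C(F)(F)F)ccc34)CC2)c2cc(Cl)ccc21` stands to compound 2 as compound 3 stands to compound 1: trifluoromethyl in place of chloro on an aromatic carbon. The two descriptions of the place agree word for word, so this is the same change made on the other core. Within the data shown here, the one measured instance of it gave no resolvable movement, and no second instance exists among the measured compounds. Because a 1.0-fold higher number from compound 1 to compound 3 (0.02 log units; within the scatter) stayed flat, the step from compound 2 to compound 4 in this assay is expected to be about a 1.0-fold higher number from compound 2 to compound 4 (0.01 log units; within the scatter). Compound 4 is accordingly estimated at 66000 nM in this assay, between 33000 nM and 130000 nM.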

Compound 4, concentration for 50% growth inhibition: 38800 nM
Estimate against measurement, compound 4: 1.7-fold (0.23 log units) above; the measured number falls inside the stated range.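

In this assay, the second instance of trifluoromethyl in place of chloro on an aromatic carbon gives a 1.7-fold lower number from compound 2 to compound 4 (0.22 log units; within the scatter), so this change produces no resolvable movement on either core. The two instances also cannot be told apart, and on these two cores the change carries over without a detectable dependence on the core: the same change on two cores in this assay, a 1.0-fold higher number (0.02 log units; within the scatter) from compound 1 to compound 3 and a 1.7-fold lower number (0.22 log units; within the scatter) from compound 2 to compound 4, 1.7-fold (0.24 log units) apart, within the scatter of two such steps This does not show that the two steps are identical or that the exchange is neutral on every core, since the result rests on a single pair per core and says nothing about cores beyond these two.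

The compounds shown leave open whether a group other than chloro or trifluoromethyl at this place, such as a nitrile, a methoxy group or an amine, would move the number beyond the scatter. Also open, going by these compounds, is how the two cores compare when their difference is broken down into single changes.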